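A furan ring in place of the fluorophenyl

The source may hold more compounds than are shown below. What is called first, only, known or untested is meant among the compounds shown, and "the series" means these compounds.

Compound 3 `CCOC(=O)c1c(C)[nH]c(=O)c(C#N)c1-c1ccc(F)cc1` gives the lowest of the two numbers shown in a functional assay on A549 cells (Homo sapiens) for inhibition, read by MTT assay, with a stated time of 24 h (on this read-out higher numbers stand for weaker inhibition and lower numbers for stronger inhibition), with 15400 nM. Compound 1 `CCOC(=O)c1c(C)[nH]c(=O)c(C#N)c1-c1ccc(OC)cc1` gives 25100 nM in this assay, and a 1.6-fold lower number from compound 1 to compound 3 (0.21 log units; within the scatter) lies within the scatter. For the measured compounds named here, compound 2 `CCOC(=O)c1c(C)[nH]c(=O)c(C#N)c1-c1ccc(C#N)cc1` reaches only a limit in this assay, > 100000 nM. an at least 6.4-fold lower number from compound 2 to compound 3 (0.81 log units; beyond the scatter) is the one step beyond the scatter, and the limit of > 100000 nM in this assay, at which 1 of the 3 values shown sits, is where compound 2 sits. Compound 4 `CCOC(=O)c1c(C)[nH]c(=O)c(C#N)c1-c1ccco1` differs from compound 3 by furan-2-yl in place of 4-fluorophenyl on an aromatic carbon. The measured steps swap one substituent for another on the ring that is now replaced; none exchanges the ring itself, so they bear on this change only loosely. The chemist expects no step beyond the scatter, a 1.3-fold higher number from compound 3 to compound 4 (0.11 log units; within the scatter), and estimates for compound 4 a value of 20000 nM, within 6000 nM to 80000 nM.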

Compound 4, half-maximal inhibitory concentration: > 100000 nM
Compound 4 ended at the assay's limit (the forecaster's own chance of this, stated with the estimate: 20%); at least 5.0-fold (0.69 log units) between middle value and limit.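

Exchanging the ring itself at this position, rather than a substituent on it, can also carry the read-out beyond the scatter: in this assay there is an at least 6.4-fold higher number from compound 3 to compound 4 (0.81 log units; beyond the scatter). The value of compound 4 is a limit, not a number, so this step gives only a minimum size. Compound 4 thus joins compound 2 at the same limit: the limit of > 100000 nM in this assay, at which 2 of the 4 values shown sit.

The compounds shown leave open whether a plain phenyl or a thiophen-2-yl ring here would stay level with compound 3 or also reach the limit. They also leave open how a carboxylic acid in place of the ethoxycarbonyl group would read.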